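The source may hold more compounds than are shown below. What is called first, only, known or untested is meant among the compounds shown, and "the series" means these compounds.

Measured compounds:
compound 1, `CC(C)NC1=NS(=O)(=O)c2cc(Cl)ccc2N1`, 36.3 uM
compound 2, `CCCNC1=NS(=O)(=O)c2cc(Cl)ccc2N1`, 55.5 uM
compound 3, `CCCNC1=NS(=O)(=O)c2cc(Br)ccc2N1`, 5.9 uM

All three were tested in a functional assay (aorta) with Rattus norvegicus as the target; a lower number here means that less compound is needed, a higher number that more compound is needed for the effect. Compound 2 and compound 3 share one core apart from a single group: bromo in place of chloro on an aromatic carbon. That change gave a 9.4-fold lower number from compound 2 to compound 3 (0.97 log units; beyond the scatter), which puts compound 3 at the lowest of the three numbers. Compound 1 differs from compound 2 by a second, separate change: isopropyl in place of propyl on an amine nitrogen. This gave a 1.5-fold lower number from compound 2 to compound 1 (0.18 log units; within the scatter), so the two cannot be ordered against each other.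

Compound 4, `CC(C)NC1=NS(=O)(=O)c2cc(Br)ccc2N1`, has not yet been tested in this assay. It stands to compound 3 exactly as compound 1 stands to compound 2: isopropyl in place of propyl on an amine nitrogen. The surroundings of the change are the same in both pairs, so this is the same change seen once more, now on the core carrying bromo. Because a 1.5-fold lower number from compound 2 to compound 1 (0.18 log units; within the scatter) stayed within the scatter, the step from compound 3 to compound 4 is expected to be small as well, about a 1.3-fold lower number from compound 3 to compound 4 (0.12 log units; within the scatter). Compound 4 is therefore expected near 4.5 uM in this assay, most likely between 1.5 uM and 13 uM.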

Compound 4, concentration for half-maximal effect: 4.8 uM
For compound 4 the middle estimate is 1.1-fold (0.03 log units) below the measured one, within the range that was stated.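

In this assay, isopropyl in place of propyl on the amine nitrogen gave a 1.2-fold lower number from compound 3 to compound 4 (0.09 log units; within the scatter), so this small step carried over from the core carrying chloro to the core carrying bromo: the same change on two cores in this assay, a 1.5-fold lower number (0.18 log units; within the scatter) from compound 2 to compound 1 and a 1.2-fold lower number (0.09 log units; within the scatter) from compound 3 to compound 4, 1.2-fold (0.09 log units) apart, within the scatter of two such steps. Bromo in place of chloro gave a 7.6-fold lower number from compound 1 to compound 4 (0.88 log units; beyond the scatter), so this larger step also carried over, from the core with the propylamino group to the core with the isopropylamino group: the same change on two cores in this assay, a 9.4-fold lower number (0.97 log units; beyond the scatter) from compound 2 to compound 3 and a 7.6-fold lower number (0.88 log units; beyond the scatter) from compound 1 to compound 4, 1.2-fold (0.09 log units) apart, within the scatter of two such steps. Together, these four compounds show that each change gave a similar step whichever form of the other group was present, but they do not show that this would hold for other groups or in other assays.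

The compounds shown leave open how a longer chain such as butyl, or a ring such as cyclopropyl, on the amine nitrogen would behave, and whether iodo or fluoro in place of bromo would shift the number. They also give no explanation of why the compounds carrying bromo have the lower numbers.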